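The source may report more compounds than this note shows. Statements on the series, on what has been measured and on what is new or still open speak of the compounds shown alone.

Measured so far: compound 1, `CCOc1c(-c2occ(C)c2C(=O)O)ccc2c(CC)cccc12`; compound 2, `CCc1cccc2c(OC)c(-c3occ(C)c3CO)ccc12`.

In a functional assay on DU-145 cells (Homo sapiens) for cytotoxicity, read by MTT assay, with a stated time of 72 h (on this read-out higher numbers stand for an effect only at larger amounts of compound and lower numbers for an effect already at smaller amounts), compound 1 gives only a limit, > 10 ug/mL. Compound 1 sits at the limit of > 10 ug/mL in this assay, at which 1 of the 2 values shown sits. In this assay compound 2 gives 7.2 ug/mL. For the measured compounds named here, compound 2 therefore holds the only number among the two measurements; the other entry is a limit.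

Compound 3, `CCOc1c(-c2occ(C)c2CO)ccc2c(CC)cccc12`, differs from compound 2 by methyl in place of hydrogen on a saturated chain carbon bound to an oxygen on an aromatic ring. Going by the values given here, no measured pair isolates this change, so no step can be read off. In this assay the expected step is none beyond the usual scatter, a 1.1-fold higher number from compound 2 to compound 3 (0.05 log units; within the scatter). Compound 3 is expected at 8 ug/mL, within 4 ug/mL to 16 ug/mL.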

Compound 3, concentration for half-maximal effect: > 10 ug/mL
Compound 3 was reported as a limit; the forecaster's own chance of this, stated with the estimate: 30%; middle value at least 1.2-fold (0.09 log units) from the limit.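

Methoxy to ethoxy is the first change isolated at this place, and in this assay it gives an at least 1.3-fold higher number from compound 2 to compound 3 (0.14 log units; that floor lies within the scatter). Compound 3 gives only a limit, so the true size of this step stays unknown: the limit of > 10 ug/mL in this assay, at which 2 of the 3 values shown sit.

The step between the two ethoxy compounds, hydroxymethyl in place of carboxy, cannot be read, as both values are limits. On these data alone, whether the methoxy to ethoxy step exceeds the scatter stays open, as does what a longer chain such as propoxy, or an amine in place of the hydroxymethyl, would give in this assay.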